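Methyl to Isopropyl at the Amide End

The compounds below may be only part of what the source reports. "The series", "measured", "known", "first", "only" and "open" are said of these compounds alone.

Measured compounds:
Compound 1 `CCCN(CC[C@H]1CC[C@H](NC(=O)/C=C/c2ccccc2OC)CC1)[C@H]1CCc2nc(N)sc2C1` gives 8.1 nM in an assay on brain for displacement of a labelled ligand from D(3) dopamine receptor (Rattus norvegicus); a lower number here means a stronger inhibitor, a higher number a weaker inhibitor.
Compound 2 `CCCN(CC[C@H]1CC[C@H](NC(=O)c2ccc(-n3ccnc3)cc2)CC1)[C@H]1CCc2nc(N)sc2C1` gives 1.9 nM.
Compound 3 `CCCN(CC[C@H]1CC[C@H](NC(=O)c2ccc(-c3noc(C)n3)cc2)CC1)[C@H]1CCc2nc(N)sc2C1` gives 1.3 nM.

Compound 3 has the lowest number of the three: the step of a 6.2-fold lower number from compound 1 to compound 3 (0.79 log units; beyond the scatter) lies beyond the scatter, while the step of a 1.5-fold lower number from compound 2 to compound 3 (0.16 log units; within the scatter) does not, so compound 2 and compound 3 cannot be ranked. Compound 4 `CCCN(CC[C@H]1CC[C@H](NC(=O)c2ccc(-c3noc(C(C)C)n3)cc2)CC1)[C@H]1CCc2nc(N)sc2C1` differs from compound 3 by isopropyl in place of methyl on an aromatic carbon. Among the compounds with values here, no measured step changes an alkyl group alone; the steps of a 4.3-fold lower number from compound 1 to compound 2 (0.63 log units; beyond the scatter) and a 6.2-fold lower number from compound 1 to compound 3 (0.79 log units; beyond the scatter) replace the whole group on the carbonyl carbon, and a 1.5-fold lower number from compound 2 to compound 3 (0.16 log units; within the scatter) swaps one five-membered ring for another without leaving the scatter. A step of no more than scatter size is therefore expected, a 1.2-fold higher number from compound 3 to compound 4 (0.09 log units; within the scatter). Compound 4 is estimated at 1.6 nM, likely between 0.5 nM and 5 nM.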

Compound 4, inhibition constant: 2 nM
Beside the measured number, compound 4's estimate is 1.3-fold (0.10 log units) below it, and the stated range covers the measured number.
By their numbers in this assay, from the lowest: compounds 3, 2 and 4 (each within the scatter of the next); then compound 1.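

In this assay, this is the only step shown that changes an alkyl group alone, and going from 5-methyl-1,2,4-oxadiazol-3-yl to 5-isopropyl-1,2,4-oxadiazol-3-yl stays within the scatter (a 1.5-fold higher number from compound 3 to compound 4 (0.19 log units; within the scatter)), so this position accepts isopropyl as readily as methyl. Compound 4 also cannot be told apart from the imidazole-bearing compound 2 (a 1.1-fold higher number from compound 2 to compound 4 (0.02 log units; within the scatter)). Nothing measured here bears on why the two alkyl groups read alike.

Going by these compounds, how much larger this group can get remains open. A tert-butyl group, a phenyl ring, an amine or a carboxylic acid at the same carbon would test that limit.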